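Lengthening a Saturated Chain: From Compound 3 to Compound 4

The source may hold more compounds than are shown below. What is called first, only, known or untested is meant among the compounds shown, and "the series" means these compounds.

Measured so far:
Compound 1, `CC(C)c1cccc(C(C)C)c1OC(=O)NC(=O)SCCCc1ccccc1`, in an assay on microsomes from intestine for inhibition of acyl-CoA:cholesterol acyltransferase (Oryctolagus cuniculus) (on this read-out lower numbers stand for stronger inhibition and higher numbers for weaker inhibition), compound 1 gives 69 nM.
Compound 2, `CCCCCCCCSC(=O)NC(=O)Oc1c(C(C)C)cccc1C(C)C`, compound 2 gives 160 nM.
Compound 3, `CCCCCCCCCCSC(=O)NC(=O)Oc1c(C(C)C)cccc1C(C)C`, compound 3 gives 130 nM.

Among these three numbers compound 3 stands second highest. Its nearest neighbour is compound 2, a difference within the usual scatter; compound 1 lies furthest away, yet that gap too is within the scatter. So on this read-out the three compounds cannot be told apart with confidence.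

Compound 4, `CCCCCCCCCCCCSC(=O)NC(=O)Oc1c(C(C)C)cccc1C(C)C`, differs from compound 3 by ethyl in place of hydrogen on a saturated chain carbon, ten or more bonds along the chain from a sulfur. Going by the values given here, the closest precedent is the step of a 1.2-fold lower number from compound 2 to compound 3 (0.09 log units; within the scatter), which added the same piece one place earlier in the chain and changed little. The steps of a 2.3-fold higher number from compound 1 to compound 2 (0.37 log units; beyond the scatter) and a 1.9-fold higher number from compound 1 to compound 3 (0.28 log units; within the scatter) swap a ring for a chain and bear less directly on a pure chain extension. For compound 4 the expected step is therefore a 1.1-fold lower number from compound 3 to compound 4 (0.03 log units; within the scatter), none beyond the scatter. Compound 4 is estimated at 120 nM, in a range from 60 nM to 250 nM.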

Compound 4, half-maximal inhibitory concentration: 16 nM
For compound 4 the middle estimate is 7.5-fold (0.88 log units) above the measured one, and the stated range ends above it.
By their numbers in this assay, from the lowest: compound 4; then compounds 1, 3 and 2 (each within the scatter of the next, the first and the last beyond it).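

Ethyl in place of hydrogen on a saturated chain carbon is far from a silent change in this assay (an 8.1-fold lower number from compound 3 to compound 4 (0.91 log units; beyond the scatter)), whereas the same piece added eight bonds along the chain changed nothing that could be told from scatter (a 1.2-fold lower number from compound 2 to compound 3 (0.09 log units; within the scatter)). Across these three chain compounds, then, the number does not fall evenly with length: the whole gain (a 10-fold lower number from compound 2 to compound 4 (1.00 log units; beyond the scatter)) arrives with the last extension. Compound 4 also overtakes the compound whose chain carries phenyl (a 4.3-fold lower number from compound 1 to compound 4 (0.63 log units; beyond the scatter)), which makes it the strongest inhibitor of the four, so in this set a ring is not needed for the lowest number.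

Nothing shown here explains why the last extension counts so much. On these data alone, whether a longer chain would lower the number further or reverse the gain stays open, as does the effect of an amine or a carboxylic acid on the chain.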